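Swapping chloro for fluoro on compound 3

A few compounds are considered here, and "the series" means these few. Any claim that something is new, unique, unknown or untested is made for them only; others in the source may bear on it.

Measured in a physicochemical assay for solubility, read by HPLC, at pH 7.4; on this read-out higher numbers stand for higher solubility and lower numbers for lower solubility:
- compound 1 `Cc1[nH]c2ccccc2c(=O)c1Cc1ccccc1`: 10000 nM
- compound 2 `Cc1[nH]c2ccc(Cl)cc2c(=O)c1Br`: 5000 nM
- compound 3 `CCCCC#Cc1c(C)[nH]c2ccc(Cl)cc2c1=O`: 2000 nM

Compound 3 has the lowest number of the three in this assay, and its gaps to compound 1 and compound 2 both lie beyond the usual scatter. Compound 4 `CCCCC#Cc1c(C)[nH]c2ccc(F)cc2c1=O` differs from compound 3 in one group: fluoro in place of chloro on an aromatic carbon. The hex-1-yn-1-yl chain stays as it is.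

For the measured compounds named here, no measured pair makes this swap, so the evidence is thin. Going by the values given here, the only measured step is a 2.5-fold lower number from compound 2 to compound 3 (0.40 log units; beyond the scatter), which is modest and comes from a different change, hex-1-yn-1-yl in place of bromo. It therefore bears on the swap only loosely, as a sense of how large one change can be in this small set. Nothing larger is expected here, and most likely no step beyond the scatter. The data give no direction, so the slight upward lean is only a judgement. The expected step is a 1.5-fold higher number from compound 3 to compound 4 (0.18 log units; within the scatter). For compound 4 the estimated value is 3000 nM, with an expected range of 1200 nM to 7000 nM.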

Compound 4, solubility: 2000 nM
Beside the measured number, compound 4's estimate is 1.5-fold (0.18 log units) above it, within the range that was stated.
By their numbers in this assay, from the lowest: compounds 3 and 4 (each within the scatter of the next); then compounds 2 and 1 (each within the scatter of the next).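

In this assay, fluoro in place of chloro on an aromatic carbon gives no change at the digits printed from compound 3 to compound 4 (within the scatter), and this is the only pair shown that differs at this position. With the hex-1-yn-1-yl chain held constant, exchanging one halogen for the other therefore leaves the read-out within the usual scatter, whereas the change at the other position, a 2.5-fold lower number from compound 2 to compound 3 (0.40 log units; beyond the scatter), lies beyond it. Nothing measured here offers an explanation for this result.

From the compounds shown here alone, it remains open whether a methoxy group, an amine or a carboxylic acid on this same aromatic carbon would shift the number in this assay. Going by these compounds, it is also open whether the chloro-to-fluoro swap would read the same with bromo, or with a shorter chain, in place of the hex-1-yn-1-yl chain.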